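The compounds below may be only part of what the source reports. "The series", "measured", "known", "first", "only" and "open" are said of these compounds alone.

Working notes on the quinoline series.

The shared core is that of compound 1 `COc1ccc(-c2cc3ccccc3nc2C=O)cc1`. In a functional assay on MDA-MB-231 cells (Homo sapiens) for antiproliferative activity, read by XTT assay, with a stated time of 72 h (a higher number here means a weaker inhibitor, a lower number a stronger inhibitor), compound 1 gives only a limit, > 10000 nM, not a number. Compound 2 `COc1ccc(C(=O)/C=C/c2nc3ccccc3cc2-c2ccc(OC)cc2)cc1` carries the enone chain and in this assay compound 2 gives 7540 nM. Compound 3 `COc1ccc(-c2cc3ccccc3nc2/C=C/C(=O)c2ccc(N)cc2)cc1` differs from compound 2 by amino in place of methoxy on an aromatic carbon; in this assay compound 3 gives 7510 nM, the step being a 1.0-fold lower number from compound 2 to compound 3 (0.00 log units; within the scatter). Among the numbers shown, compound 3 thus sits together with compound 2, and the two cannot be ordered.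

Compound 4 `COc1ccc(-c2cc3ccccc3nc2/C=C/C(=O)c2cnc(N)nc2C)cc1` is not yet measured. The change from compound 3 is 2-amino-4-methylpyrimidin-5-yl in place of 4-aminophenyl on a carbonyl carbon. Within the data shown here, the only measured step, the one from compound 2 to compound 3, touched the same ring but was a change of substituent, not of ring, and it stayed within the scatter. Among the measured compounds shown here, no measured step bears directly on a ring exchange of this kind. The expected step in this assay is therefore set at a 1.0-fold lower number from compound 3 to compound 4 (0.00 log units; within the scatter), with a wide range. For compound 4 the estimated value in this assay is 7500 nM, between 2500 nM and 22000 nM.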

Compound 4, half-maximal inhibitory concentration: > 10000 nM
Compound 4: only a limit was reported; the forecaster's own chance of this, stated with the estimate: 30%; middle value at least 1.3-fold (0.12 log units) away from the limit.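

The exchange on the carbonyl carbon is a change of ring, not of substituent, and with 2-amino-4-methylpyrimidin-5-yl in place of 4-aminophenyl the reading is an at least 1.3-fold higher number from compound 3 to compound 4 (0.12 log units; that floor lies within the scatter). Set against 4-methoxyphenyl, the same ring gives an at least 1.3-fold higher number from compound 2 to compound 4 (0.12 log units; that floor lies within the scatter). Compound 4 gives only a limit, so both steps are floors and neither has a known size, because its reading stops at the limit of the assay: the limit of > 10000 nM in this assay, at which 2 of the 4 values shown sit.

The compounds shown do not separate the ring nitrogens, the amino group and the methyl group of the entering ring, since all of them enter together. Also open, from the compounds shown here alone, is whether 2-aminopyrimidin-5-yl without the methyl, or a 4-carboxyphenyl group, would give a number at this position rather than a limit.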